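The compounds below may be only part of what the source reports. "The series", "measured", "known", "first", "only" and "open" are said of these compounds alone.

Compound 1 `O=C1c2c(ccc(O)c2O)CN1Cc1cccc(Cl)c1` and compound 3 `O=C1c2c(ccc(O)c2O)CN1Cc1ccc(F)c(Cl)c1` share one core; compound 2 `O=C1c2ccc(O)c(O)c2C(=O)N1Cc1cccc(Cl)c1` and compound 4 `O=C1c2ccc(O)c(O)c2C(=O)N1Cc1cccc(Cl)c1F` share another, and the difference between the two cores is not broken down here. In an ADME assay on HOS cells (Homo sapiens) for cytotoxicity (a higher number here means a weaker inhibitor, a lower number a stronger inhibitor), compound 1 gives 9020 nM, compound 3 gives 6870 nM and compound 2 gives 13300 nM. The step of a 1.3-fold lower number from compound 1 to compound 3 (0.12 log units; within the scatter) belongs to the change (fluoro in place of hydrogen on an aromatic carbon). The change fluoro in place of hydrogen on an aromatic carbon is of the same kind, not the same: in compound 3 the fluoro stands para to a large group, in compound 4 ortho to a large group. For the measured compounds named here, only one measured example of this kind of change exists, so the expectation rests on it alone. Because compound 1 to compound 3 gave a 1.3-fold lower number from compound 1 to compound 3 (0.12 log units; within the scatter), the step of a 1.3-fold lower number from compound 2 to compound 4 (0.10 log units; within the scatter) is expected to be of similar size in this assay. For compound 4 the estimated result in this assay is 10500 nM, expected between 5000 nM and 22000 nM.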

Compound 4, half-maximal inhibitory concentration: 11500 nM
Beside the measured number, compound 4's estimate is 1.1-fold (0.04 log units) below it, within the range that was stated.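

In this assay the new step is a 1.2-fold lower number from compound 2 to compound 4 (0.06 log units; within the scatter), so fluoro in place of hydrogen on an aromatic carbon gives no readable effect on this core either. Set beside the earlier step, the change carries from one core to the other without a detectable difference: the same change on two cores in this assay, a 1.3-fold lower number (0.12 log units; within the scatter) from compound 1 to compound 3 and a 1.2-fold lower number (0.06 log units; within the scatter) from compound 2 to compound 4, 1.1-fold (0.06 log units) apart, within the scatter of two such steps. This agreement is only between two steps within the scatter, one pair per core, with the fluoro in compound 4 ortho to a chloro group and in a different place from compound 3, so it does not show how a change with a readable effect would carry across.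

Still open, going by these compounds, is what an amine or a carboxylic acid in place of the fluoro would do in this assay. Also open, on these data alone, is whether any group on this aromatic ring moves the number beyond the scatter.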